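The compounds below may be only part of what the source reports. "The series", "measured", "known", "first", "only" and "open" are said of these compounds alone.

In a toxicity assay on the whole organism (strain Icem-CET (SPF Caw)) for cytotoxicity, with Mus musculus as the target (on this read-out lower numbers stand for an effect already at smaller amounts and higher numbers for an effect only at larger amounts of compound), compound 2 `C#CCNC(=O)/C(C)=C(\C)c1ccc(OC)cc1` gives 400 mg/kg and stands second highest of the three numbers; compound 1 `C/C(C(=O)NC1CC1)=C(\C)c1ccc(Br)cc1` gives 450 mg/kg and compound 3 `C=CCNC(=O)/C(C)=C(\C)c1ccc(OC)cc1` gives 300 mg/kg, both within the scatter of compound 2. Compound 4 `C#CCNC(=O)/C(C)=C(\C)c1ccc(F)cc1` differs from compound 2 by fluoro in place of methoxy on an aromatic carbon. Among the measured compounds shown here, the only measured single step, a 1.3-fold lower number from compound 2 to compound 3 (0.12 log units; within the scatter), concerns the amide side chain rather than the aromatic ring, so it does not bear directly on this change. Compound 1, which differs from compound 2 in more than one place, gives a value within the scatter of compound 2. Nothing measured points to a step beyond the scatter, so for compound 4 the expected change is no change at the digits printed from compound 2 to compound 4 (within the scatter). The estimate for compound 4 is 400 mg/kg, ranging from 250 mg/kg to 650 mg/kg.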

Compound 4, dose for half-maximal effect: 200 mg/kg
Beside the measured number, compound 4's estimate is 2.0-fold (0.30 log units) above it; the measured number lies below the stated range.
By their numbers in this assay, from the lowest: compounds 4, 3, 2 and 1 (each within the scatter of the next, the first and the last beyond it).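

In this assay, fluoro in place of methoxy on an aromatic carbon, para to a large group, gives a 2.0-fold lower number from compound 2 to compound 4 (0.30 log units; within the scatter). Among the compounds shown here, this is the first reading on the ring position, since the earlier single step concerned only the amide side chain, and it shows no step beyond the scatter. No evidence on hand accounts for the difference. Open, on these data alone, is whether an amine or a carboxylic acid at this position would give a step beyond the scatter. Also open, as far as these compounds go, is whether fluoro gives a similar step alongside the side chain of compound 3.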